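Swapping a bromine for a fluorine on the pendant phenyl ring

A few compounds are considered here, and "the series" means these few. Any claim that something is new, unique, unknown or untested is made for them only; others in the source may bear on it.

Two compounds share a core and differ only in the aryl group attached to it. Compound 1 `c1ccc2c(-c3cn4ccnc4c(-c4ccc5ncn(C6CCCCC6)c5c4)n3)cccc2c1` carries a naphthalen-1-yl group; in a functional assay on NCI-H226 cells (Homo sapiens) for inhibition, read by sulforhodamine B assay, with a stated time of 48 h, tested at 10 uM (on this read-out lower numbers stand for less inhibition and higher numbers for more inhibition at the one concentration tested (going by the name of the read-out)), compound 1 gives 9.45%. Compound 2 `Brc1ccc(-c2cn3ccnc3c(-c3ccc4ncn(C5CCCCC5)c4c3)n2)cc1` carries a 4-bromophenyl group, and in this assay compound 2 gives 23.3%, the higher of the two numbers, with a number 13.9 percentage points higher from compound 1 to compound 2 (beyond the scatter). Compound 3 `Fc1ccccc1-c1cn2ccnc2c(-c2ccc3ncn(C4CCCCC4)c3c2)n1` has not yet been tested. It differs from compound 2 by 2-fluorophenyl in place of 4-bromophenyl on an aromatic carbon. For the measured compounds named here, only the one step from compound 1 to compound 2 bears on this change, and it concerns a different replacement, so it says little about exchanging one halogen-bearing phenyl for another. A modest shift in either direction, or none beyond the scatter, is expected, a number 7.3 percentage points lower from compound 2 to compound 3 (within the scatter). The estimate for compound 3 in this assay is 16%, within a range from 2% to 32%.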

Compound 3, a percentage reported as inhibition, at one concentration (the size of the read-out at that concentration, not a potency): 28.7%
The estimate for compound 3 lay 12.7 percentage points below the measured number; low and high end bracket the measured number.
By their numbers in this assay, from the lowest: compound 1; then compounds 2 and 3 (each within the scatter of the next).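

At this position on the shared core, 2-fluorophenyl in place of 4-bromophenyl gives in this assay a number 5.4 percentage points higher from compound 2 to compound 3 (within the scatter), so this exchange of one halogen and its place on the phenyl ring cannot be told apart from no change. 2-fluorophenyl in place of naphthalen-1-yl gives a number 19.3 percentage points higher from compound 1 to compound 3 (beyond the scatter), which means that compound 1 now stands apart from two differently substituted phenyl groups, not just one. Nothing shown here gives a reason for these numbers.

Going by these compounds, the halogen and its place change together between compound 2 and compound 3, so the effect of each alone remains open, and 4-fluorophenyl or 2-bromophenyl would separate them. On these data alone, how a phenyl ring carrying an amine or a carboxylic acid would behave at this position also remains open.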